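This account rests on a few compounds, and the source may have more. Where it says the series, first, only, none or still open, it means among the compounds named here.

The study measures cytotoxicity in a functional assay on HepG2 cells (Homo sapiens) for cytotoxicity, read by MTT assay, with a stated time of 48 h; on this read-out lower numbers stand for stronger inhibition and higher numbers for weaker inhibition. Compound 1, with the structure `CCc1nnc(SC)n1N1C(=O)c2ccccc2C1=O`, is one of the two measured compounds. In this assay compound 1 reaches only the limit of the assay, > 200000 nM, and not a number. Compound 2 has the structure `CCCc1nnc(SCC(=O)c2ccccc2)n1N1C(=O)c2ccccc2C1=O`. In this assay compound 2 likewise reaches only the limit, > 200000 nM, so no number is known for it either. On the values shown, compound 2 therefore stands at the same place as the other measured compound, namely (the limit of > 200000 nM in this assay, at which 2 of the 2 values shown sit). Among the measured compounds shown here, no step between two measured compounds that differ in one place is available here; the two values show only that neither compound inhibited the cells within the tested range.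

Compound 3, with the structure `CCCc1nnc(SC)n1N1C(=O)c2ccccc2C1=O`, is not yet measured. It differs from compound 2 by hydrogen in place of benzoyl on a saturated chain carbon bound to a sulfur. Because compound 2 sits at the limit > 200000 nM, no change beyond the usual scatter is expected. The step that the limit leaves unreadable from compound 2 to compound 3 is thus estimated to be none beyond the scatter. Compound 3 is expected to give 300000 nM in this assay, within a range from 100000 nM to 1000000 nM, and most likely again only a limit.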

Compound 3, half-maximal inhibitory concentration: > 200000 nM
Compound 3 was reported as a limit (the forecaster's own chance of this, stated with the estimate: 85%); the middle value does not contradict the limit.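

In this assay compound 3 gives > 200000 nM, which is a limit and not a number. No step among compound 1, compound 2 and compound 3 can be read: the limit of > 200000 nM in this assay, at which 3 of the 3 values shown sit.

The compounds shown leave open whether any of them has a measurable value in this assay, and so what hydrogen in place of benzoyl does to it.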